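Removing one hydroxymethyl from the tail of compound 2

A few compounds are considered here, and "the series" means these few. Any claim that something is new, unique, unknown or untested is made for them only; others in the source may bear on it.

Compound 1 `COc1cc(C2CN(C(=O)c3cc(OCCO)ccn3)C2)ccc1OCc1ccc(C2CC2)cc1`: 51%
Compound 2 `COc1cc(C2CN(C(=O)c3cc(COCC(CO)(CO)CO)ccn3)C2)ccc1OCc1ccc(C2CC2)cc1`: 73%

In an ADME assay on S9 fraction from liver (Rattus norvegicus, strain Sprague-Dawley) for metabolic stability, read by LC-MS, using NADPH, with stated times of 5 min and 60 min, tested at 5 uM (a higher number here means that more of the compound is left, a lower number that less of the compound is left), compound 2 (73%) stands highest of the two measured compounds, and its gap to compound 1 lies beyond the usual scatter. The next compound to be tested, compound 3 `COc1cc(C2CN(C(=O)c3cc(COCC(CO)CO)ccn3)C2)ccc1OCc1ccc(C2CC2)cc1`, keeps the shared core and differs from compound 2 in one place: hydrogen in place of hydroxymethyl on a saturated chain carbon bound to three saturated chain carbons. In this way 3-hydroxy-2,2-bis(hydroxymethyl)propoxy becomes 3-hydroxy-2-(hydroxymethyl)propoxy.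

Among the compounds with values here, only one measured step bears on this, and only loosely. It is a number 22 percentage points higher from compound 1 to compound 2 (beyond the scatter), and it came with a change of the whole chain, whereas compound 3 loses a single hydroxymethyl. Only part of that step is therefore expected to be given back, and the direction is not certain with so few data. The expected change is a number 8 percentage points lower from compound 2 to compound 3 (within the scatter) in this assay. Compound 3 is estimated at 65% (expected range 48% to 82%).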

Compound 3, percent of the compound remaining: 29%
Compound 3: middle estimate off by 36 percentage points, on the high side, outside the stated range (below it).
By their numbers in this assay, from the lowest: compound 3; then compound 1; then compound 2.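

In this assay, the outcome at this position hangs on a single hydroxymethyl on the tail: the change gives a number 44 percentage points lower from compound 2 to compound 3 (beyond the scatter) even though only 2 heavy atoms leave and hydrogen takes their place. The swap away from 2-hydroxyethoxy on the aromatic carbon is also not favourable in itself, since the branched tail of compound 3 gives a number 22 percentage points lower from compound 1 to compound 3 (beyond the scatter) while the tail of compound 2, which carries one more hydroxymethyl, gives a number 22 percentage points higher from compound 1 to compound 2 (beyond the scatter) and so the sign of the step depends on that one group. No measurement at hand offers a reason for this drop.

The compounds shown leave open whether the oxygen or the carbon of the lost hydroxymethyl carries the difference, and a methyl on the same saturated chain carbon would separate the two. They also leave open how the tail would read in this assay if an amine or a carboxylic acid stood in place of a hydroxymethyl, or if a longer chain carried the same branching.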